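Dropping a Chloro Substituent: What Compound 4 Should Give

The compounds below may be only part of what the source reports. "The series", "measured", "known", "first", "only" and "open" are said of these compounds alone.

Compound 1, `CC1=NN(c2cccc(Cl)c2)C(=O)C12C=CC(=O)C=C2c1cccc(C)c1`: 20100 nM
Compound 2, `CC1=NN(c2ccccc2)C(=O)C12C=CC(=O)C=C2c1cccc(C)c1`: 16500 nM
Compound 3, `CC1=NN(c2ccc(Cl)cc2)C(=O)C12C=CC(=O)C=C2c1ccc(C)cc1`: 33400 nM

In a functional assay on A549 cells (Homo sapiens) for antiproliferative activity, read by CCK-8 assay, with a stated time of 72 h (on this read-out higher numbers stand for weaker inhibition and lower numbers for stronger inhibition), compound 1 gives 20100 nM. Compound 2 differs by hydrogen in place of chloro on an aromatic carbon, and the step is a 1.2-fold lower number from compound 1 to compound 2 (0.09 log units; within the scatter). Compound 3 carries the same atoms as compound 1 joined differently; the difference between the two cores is not broken down here. Compound 3 gives 33400 nM, within the scatter of compound 1 but beyond it relative to compound 2.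

Compound 4, `CC1=NN(c2ccccc2)C(=O)C12C=CC(=O)C=C2c1ccc(C)cc1`, differs from compound 3 by hydrogen in place of chloro on an aromatic carbon. It is the same kind of change as between compound 1 and compound 2, but the chloro sits para rather than meta to a large group. Because a 1.2-fold lower number from compound 1 to compound 2 (0.09 log units; within the scatter) was within the scatter, compound 4 is expected to show a similarly small step, a 1.2-fold lower number from compound 3 to compound 4 (0.08 log units; within the scatter), giving an estimated 28000 nM, roughly between 12000 nM and 60000 nM.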

Compound 4, half-maximal inhibitory concentration: 19300 nM
Compound 4: middle estimate off by 1.5-fold (0.16 log units), on the high side; the range from low to high includes it.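

Replacing chloro with hydrogen gives a 1.7-fold lower number from compound 3 to compound 4 (0.24 log units; within the scatter), and 4-methylphenyl in place of 3-methylphenyl gives a 1.2-fold higher number from compound 2 to compound 4 (0.07 log units; within the scatter). Set beside the earlier step, the change from chloro to hydrogen reads alike on both cores in this assay: the same change on two cores in this assay, a 1.2-fold lower number (0.09 log units; within the scatter) from compound 1 to compound 2 and a 1.7-fold lower number (0.24 log units; within the scatter) from compound 3 to compound 4, 1.4-fold (0.15 log units) apart, within the scatter of two such steps So the change carries from one core to the other here without a detectable difference, but both steps lie inside the scatter, so this does not show that removing the chloro has a real effect, and two cores set no rule for the series.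

Going by these compounds, whether an amine, a methoxy group or a carboxylic acid in place of the chloro would give a larger step remains open.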